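The source may hold more compounds than are shown below. What is called first, only, known or untested is meant among the compounds shown, and "the series" means these compounds.

Going by the values given here, compound 2 `O=C(/C=C/c1cc2ccccc2[nH]c1=O)c1ccc(O)cc1` is the only member of this small set with a numerical result: in an ADME assay on EKVX cells (Homo sapiens) for cytotoxicity, read by sulforhodamine B assay, with a stated time of 24 h (on this read-out lower numbers stand for higher toxicity in this test and higher numbers for lower toxicity in this test), compound 2 gives 55200 nM. Its neighbour compound 1 `COc1ccc(C(=O)/C=C/c2cc3ccccc3[nH]c2=O)cc1` returns only a limit of the assay, > 100000 nM. Among the compounds with values here, the one measured step, an at least 1.8-fold lower number from compound 1 to compound 2 (0.25 log units; that floor lies within the scatter), therefore rests on the limit of > 100000 nM in this assay, at which 1 of the 2 values shown sits, and cannot be sized beyond its floor. Compound 3 `O=C(/C=C/c1cc2ccccc2[nH]c1=O)c1ccc(Cl)cc1` changes the same position of the shared core in another way, (chloro in place of hydroxy on an aromatic carbon). Within the data shown here, no measured step carries a chloro group, so the only guidance is that swapping the substituent on this ring between compound 1 and compound 2 moved the number by no more than the scatter allows to be claimed. A change of comparable, modest size is expected for a 1.4-fold lower number from compound 2 to compound 3 (0.14 log units; within the scatter). Compound 3 is therefore estimated at 40000 nM, with a range from 12000 nM to 100000 nM.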

Compound 3, concentration lethal to 50% of the cells: > 100000 nM
Compound 3: a limit, no number (the forecaster's own chance of this, stated with the estimate: 25%); at least 2.5-fold (0.39 log units) between middle value and limit.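

At this position of the shared core, the change from 4-hydroxyphenyl to 4-chlorophenyl in this assay gives an at least 1.8-fold higher number from compound 2 to compound 3 (0.25 log units; that floor lies within the scatter), and its size cannot be read beyond that floor. Compound 3 returns a limit, > 100000 nM, and not a number. The earlier compounds did not show that a second replacement of the hydroxy group would also end at the limit, which leaves the hydroxy group of compound 2 with the only numerical result here, while the step between the two compounds at the limit cannot be read: the limit of > 100000 nM in this assay, at which 2 of the 3 values shown sit.

The compounds shown leave open whether compound 2 truly differs from the other two, for the floors of both readable steps lie within the scatter. Going by these compounds, it also remains open whether an amine or a carboxylic acid on this ring would give a number in this test.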